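The compounds below may be only part of what the source reports. "The series", "measured", "known", "first", "only" and "open" are said of these compounds alone.

Of the compounds shown here, two have been measured in an in vitro functional assay on HEK ts201 cells for antagonist activity at Neuronal acetylcholine receptor; alpha4/beta2 (Homo sapiens), read by fluorescence and calcium flux; a lower number here means a stronger inhibitor, a higher number a weaker inhibitor. Compound 1, whose structure is `O=C(NCc1ccccc1)c1ccccc1-c1ccccc1`, gives in this assay a half-maximal inhibitory concentration of 7500 nM. Compound 2, with the structure `CC1CC(=O)N(c2ccccc2C(=O)OCC2CCCN(CCCCOc3ccc(Cl)c(Cl)c3)C2)C1=O`, gives in this assay a value of 12300 nM. Compound 2 has the higher of the two numbers, but the gap to compound 1 lies within the usual scatter of repeated measurements, so the two compounds cannot be told apart on these data; both are weak inhibitors.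

Compound 3 has the structure `COc1ccc(OCCCCCN2CCCC(COC(=O)c3ccccc3N3C(=O)CC(C)C3=O)C2)cc1`. It differs from compound 2 in one place: (4-methoxyphenoxy)methyl in place of 3,4-dichlorophenoxy on a saturated chain carbon, four bonds along the chain from an amine nitrogen in a ring. Within the data shown here, no measured pair shows what such a change does in this assay, so there is nothing to anchor the size or direction of the step beyond the two values already given.

Given the lack of any comparable step, compound 3 is expected to stay close to compound 2, with the step from a 1.2-fold higher number from compound 2 to compound 3 (0.09 log units; within the scatter) expected to remain within the scatter. The estimate for compound 3 in this assay is therefore 15000 nM, with a range from 5000 nM to 45000 nM.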

Compound 3, half-maximal inhibitory concentration: 14500 nM
For compound 3 the middle estimate is 1.0-fold (0.01 log units) above the measured one; measured number inside the range.
By their numbers in this assay, from the lowest: compounds 1, 2 and 3 (each within the scatter of the next).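

In this assay, placing (4-methoxyphenoxy)methyl in place of 3,4-dichlorophenoxy on a saturated chain carbon, four bonds along the chain from an amine nitrogen in a ring, gives a 1.2-fold higher number from compound 2 to compound 3 (0.07 log units; within the scatter). Among these compounds, this is the first measured pair at this position, and the two compounds cannot be told apart, even though both chlorine atoms leave and a methoxy group enters. Cut one bond further out, the same difference reads (3,4-dichlorophenoxy)methyl to 2-(4-methoxyphenoxy)ethyl, so the ring substituents and the chain length differ together in this one step, and the data give no explanation for the result.

A single pair cannot show whether the swap of ring substituents and the difference in chain length each have no effect or whether two effects happen to offset each other. It also leaves open whether a quite different group on the same chain carbon, such as an amine or a carboxylic acid in place of the phenoxy group, would move the number beyond the usual scatter.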